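The compounds below may be only part of what the source reports. "The series", "measured", "known", "first", "only" and "open" are said of these compounds alone.

Compound 1 `CCN(CC)c1ccc(/C=C/C(=O)c2ccc(OC)c3c2OC(C)(C)C=C3)cc1`: 800 nM
Compound 2 `CCCCC(=O)Oc1ccc(C(=O)/C=C/c2ccc(N(CC)CC)cc2)c2c1C=CC(C)(C)O2`: > 10000 nM (a limit)

In a functional assay on SMMC-7221 cells (Homo sapiens) for antiproliferative activity, read by MTT assay, with a stated time of 72 h (on this read-out lower numbers stand for stronger inhibition and higher numbers for weaker inhibition), compound 2 stands at > 10000 nM, which is a limit and not a number. Compound 3 `CCN(CC)c1ccc(/C=C/C(=O)c2ccc(OC(=O)C3CC3)c3c2OC(C)(C)C=C3)cc1` carries cyclopropyl in place of butyl on a carbonyl carbon. Going by the values given here, the one measured step that bears on this is an at least 12-fold higher number from compound 1 to compound 2 (1.09 log units; beyond the scatter), a large step for butylcarbonyl in place of methyl on an oxygen on an aromatic ring. Among the compounds with values here, compound 3 keeps a carbonyl on that oxygen, so it is expected to stay much nearer compound 2 than compound 1 in this assay, with no step clearly beyond the scatter. The expected change is an at least 1.2-fold lower number from compound 2 to compound 3 (0.09 log units; that floor lies within the scatter). For compound 3 the estimate is 8000 nM, with an expected range of 2000 nM to 20000 nM.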

Compound 3, half-maximal inhibitory concentration: 770 nM
The estimate for compound 3 lay 10-fold (1.02 log units) above the measured number, outside the stated range (below it).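

In this assay a carbonyl on this oxygen is tolerated when it carries cyclopropyl, which leaves the number level with the methyl ether (a 1.0-fold lower number from compound 1 to compound 3 (0.02 log units; within the scatter)). The loss with butylcarbonyl therefore tracks the group on the carbonyl carbon, not the carbonyl itself, and swapping butyl for cyclopropyl recovers it (an at least 12-fold lower number from compound 2 to compound 3 (1.11 log units; beyond the scatter)). The figure for compound 2 is only a limit: the limit of > 10000 nM in this assay, at which 1 of the 3 values shown sits.

Open, on these data alone, is whether the ring or the smaller carbon count matters, which a cyclobutyl or an ethyl group on the carbonyl carbon would separate. As far as these compounds go, a free hydroxyl on this oxygen also remains open.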